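The compounds below may be only part of what the source reports. "The series", "measured", "known", "first", "only" and "open" are said of these compounds alone.

Measured so far:
- compound 1, `CC(C)n1ncc2c(C(=O)NCc3cn(-c4ccc(I)cc4)nn3)cccc21`: > 40000 nM (a limit of the assay)
- compound 2, `CC(C)n1ncc2c(C(=O)NCc3cn(Cc4ccc(C#N)cc4)nn3)cccc21`: > 40000 nM (a limit of the assay)

In a functional assay on MCF7 cells (Homo sapiens) for inhibition, read by MTT assay, with a stated time of 72 h (a higher number here means a weaker inhibitor, a lower number a stronger inhibitor), compound 1 gives > 40000 nM, which is a limit, not a number. In this assay compound 2 likewise gives > 40000 nM, again a limit. The step that the two limits leave unreadable from compound 1 to compound 2 therefore cannot be read, both values resting at the limit of > 40000 nM in this assay, at which 2 of the 2 values shown sit. Compound 3, `COc1ccc(Cn2cc(CNC(=O)c3cccc4c3cnn4C(C)C)nn2)cc1`, differs from compound 2 by methoxy in place of cyano on an aromatic carbon. Within the data shown here, no measured step bears on this change, and compound 2 stands only at a limit, so the step that the limit leaves unreadable from compound 2 to compound 3 is expected to show nothing readable. Compound 3 is estimated at 60000 nM, within 15000 nM to 200000 nM.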

Compound 3, half-maximal inhibitory concentration: > 40000 nM
Compound 3: only a limit was reported (the forecaster's own chance of this, stated with the estimate: 85%); the middle value does not contradict the limit.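

Among these compounds, no step among compound 1, compound 2 and compound 3 can be read, as all three values are limits: the limit of > 40000 nM in this assay, at which 3 of the 3 values shown sit. The compounds shown leave open whether any group at this place on the shared core gives a readable value.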